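From methoxy to ((pyridin-4-yl)carbonyl)amino on a double-bonded nitrogen

A few compounds are considered here, and "the series" means these few. Any claim that something is new, unique, unknown or untested is made for them only; others in the source may bear on it.

In an ADME assay on Vero cells (Chlorocebus sabaeus) for cytotoxicity, read by MTT assay, with a stated time of 72 h (a higher number here means that more compound is tolerated, a lower number that less compound is tolerated), compound 1 `COC(=O)CN1CCN(c2c(F)cc3c(=O)c(C(=O)O)cn(C4CC4)c3c2OC)CC1C` gives 500 ug/mL and compound 2 `CO/N=C(\C)CN1CCN(c2c(F)cc3c(=O)c(C(=O)O)cn(C4CC4)c3c2OC)CC1C` gives 49.6 ug/mL, the lower of the two numbers. Compound 3 `COc1c(N2CCN(C/C(C)=N/NC(=O)c3ccncc3)C(C)C2)c(F)cc2c(=O)c(C(=O)O)cn(C3CC3)c12` has ((pyridin-4-yl)carbonyl)amino in place of methoxy on a double-bonded nitrogen. For the measured compounds named here, the one measured step, a 10-fold lower number from compound 1 to compound 2 (1.00 log units; beyond the scatter), bears only loosely on this change, and no measured compound carries the entering group. No shift in a known direction can be argued, so the expected step stays within the scatter: a 1.2-fold higher number from compound 2 to compound 3 (0.08 log units; within the scatter). Compound 3 is estimated at 60 ug/mL, with an expected range of 15 ug/mL to 250 ug/mL.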

Compound 3, half-maximal cytotoxic concentration: 250 ug/mL
The estimate for compound 3 lay 4.2-fold (0.62 log units) below the measured number; measured number inside the range.
By their numbers in this assay, from the lowest: compound 2; then compounds 3 and 1 (each within the scatter of the next).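

In this assay, ((pyridin-4-yl)carbonyl)amino in place of methoxy on a double-bonded nitrogen gives a 5.0-fold higher number from compound 2 to compound 3 (0.70 log units; beyond the scatter), so the number responds to the group on this nitrogen and the low value of compound 2 does not hold for every group there. The wider change gives a 2.0-fold lower number from compound 1 to compound 3 (0.30 log units; within the scatter), which sets no order between these two compounds. Nothing available accounts for the shift.

Still open, on these data alone, is whether the shift follows the aromatic ring or the carbonyl and amide hydrogen of the entering group. A benzoylamino or acetylamino group on the same nitrogen would separate these.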